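Swapping a trifluoromethyl for bromo on the aniline

A few compounds are considered here, and "the series" means these few. Any claim that something is new, unique, unknown or untested is made for them only; others in the source may bear on it.

Measured compounds and their values:
compound 1, `COc1cc2ncnc(Nc3ccc(Cl)c(C(F)(F)F)c3)c2cc1OCCCCC(=O)Nc1ccc(S(N)(=O)=O)cc1`, 3220 nM;
compound 2, `COc1cc2ncnc(Nc3ccc(C(F)(F)F)cc3)c2cc1OCCCCC(=O)Nc1ccc(S(N)(=O)=O)cc1`, 12000 nM;
compound 3, `NS(=O)(=O)c1ccc(NC(=S)Nc2ccc3ncnc(Nc4cccc(C(F)(F)F)c4)c3c2)cc1`, 7590 nM.

These three compounds were tested in a functional assay on NCI-H1975 cells (Homo sapiens) for antiproliferative activity, read by MTT assay, with a stated time of 72 h; on this read-out higher numbers stand for weaker inhibition and lower numbers for stronger inhibition. Compound 3 stands second highest of the three numbers: its nearest neighbour is compound 2, whose value lies within the scatter of that of compound 3, while compound 1 gives a lower number that lies beyond the scatter from compound 3.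

Compound 4, `NS(=O)(=O)c1ccc(NC(=S)Nc2ccc3ncnc(Nc4cccc(Br)c4)c3c2)cc1`, has not yet been measured. It differs from compound 3 in one place: bromo in place of trifluoromethyl on an aromatic carbon. Among the compounds with values here, the only step recorded among the measured compounds, a 3.7-fold higher number from compound 1 to compound 2 (0.57 log units; beyond the scatter), concerns a different pair of groups on a different core and says nothing direct about a bromo replacing a trifluoromethyl. Within the data shown here, with no step that bears on this change, the expectation for compound 4 rests on compound 3 alone and on the small size of the change. The account therefore expects compound 4 to move by a 1.2-fold lower number from compound 3 to compound 4 (0.07 log units; within the scatter) in this assay, which is to say no step beyond the scatter. Compound 4 is estimated at 6500 nM, with a range from 2500 nM to 17000 nM.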

Compound 4, half-maximal inhibitory concentration: 11000 nM
For compound 4 the middle estimate is 1.7-fold (0.23 log units) below the measured one; the measured number falls inside the stated range.
By their numbers in this assay, from the lowest: compound 1; then compounds 3, 4 and 2 (each within the scatter of the next).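

In this assay, the exchange at this aromatic carbon gives a 1.4-fold higher number from compound 3 to compound 4 (0.16 log units; within the scatter) and so shows that, on the core shared by these two compounds, one bromine atom can take the place of the four heavy atoms of trifluoromethyl without a step that stands clear of the scatter. Within the data shown here, the earlier compounds gave no reading of this exchange: their only recorded step, a 3.7-fold higher number from compound 1 to compound 2 (0.57 log units; beyond the scatter), lies beyond the scatter but concerns other groups on a different core, so the present result is the first information about the 3-(trifluoromethyl)phenyl to 3-bromophenyl change. No measurement shown here offers an explanation for how these two groups compare in this assay.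

Going by these compounds, it remains open whether other groups on the same aromatic carbon, such as chloro, methoxy, nitrile or an amine, would also stay within the scatter of compound 3 or would move the number beyond it. On these data alone, it also remains open whether bromo in place of trifluoromethyl would give a similar step on the core of compound 1, which carries a different chain and a different substitution on its aniline.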